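The source may report more compounds than this note shows. Statements on the series, on what has been measured and on what is new or still open speak of the compounds shown alone.

Among the measured compounds shown here, in a functional assay on K562 cells (Homo sapiens) for antiproliferative activity, read by MTT assay, with a stated time of 48 h (on this read-out lower numbers stand for stronger inhibition and higher numbers for weaker inhibition), compound 1 `Oc1ccc2c(c1)CCc1ccc(O)c(c1)Oc1ccc(cc1)CCc1cccc(O)c1O2` gives 14100 nM, the higher of the two numbers measured so far, while compound 2 `Oc1cc2c(cc1O)Oc1c(O)cccc1CCc1ccc(cc1)Oc1cc(ccc1O)CC2` gives 6160 nM. Compound 3 `Oc1ccc2c(c1)CCc1ccc(O)c(c1)Oc1ccc(cc1O)CCc1cccc(O)c1O2` is still unmeasured and differs from compound 1 by hydroxy in place of hydrogen on an aromatic carbon. For the measured compounds named here, the only measured step of this kind, made at a different place on the core, is modest: a 2.3-fold lower number from compound 1 to compound 2 (0.36 log units; beyond the scatter). One step is thin support, but a similar modest lowering is expected, estimated as a 2.2-fold lower number from compound 1 to compound 3 (0.34 log units; beyond the scatter). Compound 3 is expected at 6500 nM, with an estimated range of 2200 nM to 19000 nM.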

Compound 3, half-maximal inhibitory concentration: 25300 nM
Compound 3: middle estimate off by 3.9-fold (0.59 log units), on the low side; measured number above the stated range.
By their numbers in this assay, from the lowest: compound 2; then compounds 1 and 3 (each within the scatter of the next).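

In this assay, hydroxy in place of hydrogen at this position, ortho to a fused ring and meta to a fused ring, gives a 1.8-fold higher number from compound 1 to compound 3 (0.25 log units; within the scatter) and so stays within the scatter. The modest lowering seen elsewhere on the core, a 2.3-fold lower number from compound 1 to compound 2 (0.36 log units; beyond the scatter), therefore does not carry over to this position, and the same exchange cannot be read as equivalent at both places. Nothing available explains this difference between the two places. The compounds shown leave open whether a methoxy group, an amine or a fluorine atom at this position would move the number beyond the scatter.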